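The source may report more compounds than this note shows. Statements on the series, on what has been measured and on what is new or still open speak of the compounds shown alone.

Working notes on the series: the group on the carbonyl carbon of the shared core varies across compound 1 `O=C(c1ccc(-c2cc(F)c3ncc(Cc4ccc5ncccc5c4)n3c2)cc1F)N1CCC2(COC2)C1`, compound 2 `CN1CCN(C(=O)c2ccc(-c3cc(F)c4ncc(Cc5ccc6ncccc6c5)n4c3)cc2F)CC1` and compound 3 `O=C(NC1CCCNC1)c1ccc(-c2cc(F)c3ncc(Cc4ccc5ncccc5c4)n3c2)cc1F`. In a functional assay on EBC-1 cells (Homo sapiens) for antiproliferative activity, with a stated time of 72 h (a higher number here means a weaker inhibitor, a lower number a stronger inhibitor), compound 1 gives 406 nM, compound 2 gives 869 nM and compound 3 gives 138 nM, the lowest of the three. Compound 4 `O=C(NC1CCOCC1)c1ccc(-c2cc(F)c3ncc(Cc4ccc5ncccc5c4)n3c2)cc1F` follows from compound 3 with oxan-4-yl in place of piperidin-3-yl on an amide-type nitrogen. For the measured compounds named here, no measured step makes this exact exchange. The closest evidence comes from changes at the same carbonyl carbon, a 2.9-fold lower number from compound 1 to compound 3 (0.47 log units; beyond the scatter) and a 6.3-fold lower number from compound 2 to compound 3 (0.80 log units; beyond the scatter), both modest. A modest move to a higher number in this assay is therefore expected, with the expected step being a 2.2-fold higher number from compound 3 to compound 4 (0.34 log units; beyond the scatter). For compound 4 the estimated value is 300 nM, with an expected range from 120 nM to 750 nM.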

Compound 4, half-maximal inhibitory concentration: 70.5 nM
Estimate against measurement, compound 4: 4.3-fold (0.63 log units) above, outside the stated range (below it).
By their numbers in this assay, from the lowest: compounds 4 and 3 (each within the scatter of the next); then compound 1; then compound 2.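

In this assay the exchange of piperidin-3-yl for oxan-4-yl on the amide-type nitrogen gives a 2.0-fold lower number from compound 3 to compound 4 (0.29 log units; within the scatter) and stays within the scatter, so a ring nitrogen is not required at this position to hold the number of compound 3. Compounds 3 and 4, which both keep the amide hydrogen, also both lie beyond the scatter from the two compounds without it, with a 12-fold lower number from compound 2 to compound 4 (1.09 log units; beyond the scatter) and a 5.8-fold lower number from compound 1 to compound 4 (0.76 log units; beyond the scatter) for the new compound. No measurement at hand explains these steps.

The exchange alters both the ring hetero atom and its attachment point, and piperidin-4-yl would separate the two. On these data alone, how an open-chain ether or a carboxylic acid on the amide-type nitrogen would compare remains open.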